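A few compounds are considered here, and "the series" means these few. Any claim that something is new, unique, unknown or untested is made for them only; others in the source may bear on it.

Working notes on the series. Two compounds carry numbers in an assay on mitochondria for inhibition of Amine oxidase [flavin-containing] B (Bos taurus); a lower number here means a stronger inhibitor, a higher number a weaker inhibitor. Compound 1 `Cc1csc(N/N=C/c2ccc(Cl)cc2)n1` gives 9.12 nM in this assay, and compound 2 `COc1ccc(/C=N/Nc2nc(C)cs2)cc1` gives 4.07 nM. For the measured compounds named here, the single step between them, a 2.2-fold lower number from compound 1 to compound 2 (0.35 log units; beyond the scatter), is modest though beyond the scatter. On these two numbers compound 2 stands lowest, with compound 1 as its nearest neighbour at a number higher by that step.

Compound 3 `COc1ccc(/C=N/Nc2nc(C)cs2)cc1OC` is the next structure and has no number yet. It differs from compound 2 by methoxy in place of hydrogen on an aromatic carbon. Going by the values given here, no measured step covers this particular change. Among the compounds with values here, the one step in hand, a 2.2-fold lower number from compound 1 to compound 2 (0.35 log units; beyond the scatter), replaces one group by another on the same ring rather than adding a group in place of hydrogen, so it bears on the question only loosely: it shows that altering the substitution of that ring moved the number modestly. A step of comparable or smaller size is therefore expected for compound 3, in either direction, with no firm case for one beyond the scatter. The estimate for compound 3 in this assay is 5 nM, ranging from 2 nM to 15 nM, which means an expected step of a 1.2-fold higher number from compound 2 to compound 3 (0.09 log units; within the scatter).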

Compound 3, inhibition constant: 7.08 nM
Compound 3: middle estimate off by 1.4-fold (0.15 log units), on the low side; low and high end bracket the measured number.
By their numbers in this assay, from the lowest: compounds 2, 3 and 1 (each within the scatter of the next, the first and the last beyond it).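

In this assay, methoxy in place of hydrogen on an aromatic carbon, ortho to a methoxy group and meta to a group of 9 heavy atoms, gives a 1.7-fold higher number from compound 2 to compound 3 (0.24 log units; within the scatter) and leaves the two numbers within the scatter of each other. For the compounds shown here, this is the first look at a group added in place of hydrogen on this ring, whereas a 2.2-fold lower number from compound 1 to compound 2 (0.35 log units; beyond the scatter) exchanged one group for another, and it shows that this position can carry a methoxy of 2 heavy atoms alongside the existing methoxy without a difference that can be told from the scatter. Nothing available bears on the reason for this result.

The compounds shown leave open whether this tolerance extends beyond methoxy, for instance to a hydroxyl, an amine, a carboxylic acid or a longer alkoxy chain such as butoxy at the same carbon. They also leave open how a methoxy at this position would read without the existing methoxy, since here the two occur only together.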